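A few compounds are considered here, and "the series" means these few. Any claim that something is new, unique, unknown or untested is made for them only; others in the source may bear on it.

Compound 1 `O=C1Nc2ccc(C(=O)c3ccco3)cc2/C1=C/c1cc(Br)cc(Br)c1`: 16%
Compound 2 `O=C1Nc2ccc(C(=O)c3ccco3)cc2/C1=C/c1ccc(Br)c(O)c1`: -5.6%

In an assay on HeLa cells for inhibition of Kinesin-like protein KIF15 (Homo sapiens), read by microscopy, with stated times of 2 s and 20 s, tested at 750 nM (on this read-out higher numbers stand for more inhibition at the one concentration tested (going by the name of the read-out) and lower numbers for less inhibition), compound 2 gives the lower of the two numbers, a difference beyond the scatter of the method. Within the data shown here, the only measured step is a number 21.6 percentage points lower from compound 1 to compound 2 (beyond the scatter), where one aryl ring on the double-bonded chain carbon replaced another. Compound 3 `O=C1Nc2ccc(C(=O)c3ccco3)cc2/C1=C/c1ccc(O)nc1` differs from compound 2 by 6-hydroxypyridin-3-yl in place of 4-bromo-3-hydroxyphenyl on a double-bonded chain carbon bound to a double-bonded ring carbon. Among the measured compounds shown here, no measured step shares this exchange, so the expectation rests on little: the step is estimated as a number 7.6 percentage points higher from compound 2 to compound 3 (within the scatter), likely not beyond the scatter. Compound 3 is therefore expected to give about 2%, between -18% and 22%.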

Compound 3, a percentage reported as inhibition, at one concentration (the size of the read-out at that concentration, not a potency): 26.5%
Compound 3: the middle estimate sits 24.5 percentage points below what was measured; the whole stated range lies below it.
By their numbers in this assay, from the lowest: compound 2; then compound 1; then compound 3.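

The ring on the double-bonded chain carbon need not carry bromine: 6-hydroxypyridin-3-yl in place of 4-bromo-3-hydroxyphenyl gives a number 32.1 percentage points higher from compound 2 to compound 3 (beyond the scatter) in this assay. The same group in place of 3,5-dibromophenyl gives a number 10.5 percentage points higher from compound 1 to compound 3 (beyond the scatter), so a ring with one hetero atom tops both bromine-bearing rings here. Nothing available explains these differences.

On these data alone, whether the hydroxyl of the new ring is needed remains open, for instance against an amine at that spot. As far as these compounds go, with one concentration per compound, potency also remains unknown.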